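Benzoyl hydrazones: para-methyl probe on the terminal phenyl

A few compounds are considered here, and "the series" means these few. Any claim that something is new, unique, unknown or untested is made for them only; others in the source may bear on it.

Compound 1 `Cc1cc2c(cc1C)C(Cl)=C(/C=N\NC(=O)C1=C(Cl)c3ccccc3CCC1)CCC2` gives 210 nM in a functional assay (MiaPaCa cells, Homo sapiens) for inhibition, read by sulforhodamine B assay, with a stated time of 48 h; a lower number here means a stronger inhibitor of growth, a higher number a weaker inhibitor of growth. Compound 2 `O=C(N/N=C/C1=C(Cl)c2ccccc2CCC1)c1cccnc1`, with a pyridyl amide, gives 11700 nM in this assay. Compound 3 `Cc1cc2c(cc1C)C(Cl)=C(/C=N/NC(=O)c1ccccc1)CCC2` returns only a limit in this assay, > 100000 nM, so compound 3 stands at the limit of > 100000 nM in this assay, at which 1 of the 3 values shown sits, and no number is known for it. Compound 4 `Cc1ccc(C(=O)N/N=C/C2=C(Cl)c3cc(C)c(C)cc3CCC2)cc1` is not yet measured; it differs from compound 3 by methyl in place of hydrogen on an aromatic carbon, a methyl in place of hydrogen on an aromatic carbon, para to a large group. Among the compounds with values here, no measured pair covers such a change, so the step from compound 3 to compound 4 is expected to be small, with no clear direction and likely within the scatter, as an at least 1.2-fold lower number from compound 3 to compound 4 (0.09 log units; that floor lies within the scatter). Compound 4 is therefore estimated at 80000 nM, between 15000 nM and 300000 nM, and may again come back only as a limit.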

Compound 4, concentration for 50% growth inhibition: 28800 nM
Beside the measured number, compound 4's estimate is 2.8-fold (0.44 log units) above it; the range from low to high includes it.
By their numbers in this assay, from the lowest: compound 1; then compound 2; then compound 4. At a limit, above all of these: compound 3.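

In this assay, phenyl to 4-methylphenyl gives an at least 3.4-fold lower number from compound 3 to compound 4 (0.54 log units; beyond the scatter), the first step read at this position. With a single methyl, para to a large group, compound 4 gives 28800 nM. The step is only a floor, and its full size cannot be read: the limit of > 100000 nM in this assay, at which 1 of the 4 values shown sits.

On these data alone, whether methoxy, chlorine or a carboxylic acid in place of this methyl moves the number the same way stays open. As far as these compounds go, the effect of a methyl on another carbon of this ring also stays open.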